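The compounds below may be only part of what the source reports. "The series", "measured", "known", "first", "only" and "open" are said of these compounds alone.

Measured compounds in a functional assay on DU-145 cells (Homo sapiens) for inhibition, read by MTT assay, with stated times of 18 h and 4 h; on this read-out higher numbers stand for weaker inhibition and lower numbers for stronger inhibition:
- compound 1, `CCCCCCCCOP(=O)(O)OCCSC(=S)N1CCCCC1`: > 100000 nM (a limit of this assay, not a number)
- compound 2, `CCCCCCCCOP(=O)(O)OCCSC(=S)N1CCCCCC1`: 59100 nM
- compound 3, `CCCCCCCCCCOP(=O)(O)OCCSC(=S)N1CCCCC1`: 29300 nM

Compound 3 and compound 1 share the same core and differ in one place: hydrogen in place of ethyl on a saturated chain carbon, eight bonds along the chain from an oxygen on an unsaturated carbon. In this assay the step is an at least 3.4-fold higher number from compound 3 to compound 1 (0.53 log units; beyond the scatter). That step rests on a limit, (the limit of > 100000 nM in this assay, at which 1 of the 3 values shown sits); its true size is not known, only its floor.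

Compound 1 and compound 2 differ in the ring on the thiocarbonyl carbon, and the step is an at least 1.6-fold lower number from compound 1 to compound 2 (0.22 log units; that floor lies within the scatter). Compound 2 and compound 3 differ in more than one place, so the difference between their cores is not broken down here; what their two values show is a gap that lies within the usual scatter, so no order between them is read.

Compound 4, `CCCCCCOP(=O)(O)OCCSC(=S)N1CCCCCC1`, has not yet been measured in this assay. It differs from compound 2 in one place: hydrogen in place of ethyl on a saturated chain carbon, six bonds along the chain from an oxygen on an unsaturated carbon. This is the same kind of change as from compound 3 to compound 1, but not the same: there the place was eight bonds along the chain from an oxygen on an unsaturated carbon, here it is six bonds along the chain from that oxygen. With only one such step shown, and that one known only as a floor, the expected step is a 3.4-fold higher number from compound 2 to compound 4 (0.53 log units; beyond the scatter). For compound 4 the estimate in this assay is 200000 nM, with a range from 80000 nM to 600000 nM; a limit rather than a number is quite likely.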

Compound 4, half-maximal inhibitory concentration: 77400 nM
Estimate against measurement, compound 4: 2.6-fold (0.41 log units) above, outside the stated range (below it).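

On the core of compound 2 in this assay, hydrogen in place of ethyl gives a 1.3-fold higher number from compound 2 to compound 4 (0.12 log units; within the scatter), so on this core the change leaves the value within the usual scatter. Carrying the change from one core to the other is therefore not established, and a difference between the two cores is not established either, with the change also sitting six bonds along the chain here and eight bonds along it on the other core: the same change on two cores in this assay, an at least 3.4-fold higher number (0.53 log units; beyond the scatter) from compound 3 to compound 1 and a 1.3-fold higher number (0.12 log units; within the scatter) from compound 2 to compound 4; the limit leaves it open whether they differ. Among the compounds shown here, compound 1 gives > 100000 nM, which is a limit of this assay and not a number, so the step on its core has a known floor but no known size, and the series shows only that this step clears the scatter while the step on the core of compound 2 does not.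

Still open is how the values run with a longer chain than any shown on the core of compound 2, and what a shorter chain does on the core of compound 1. Also open, going by these compounds, is whether the same change behaves alike with a morpholine ring or an open-chain diethylamine on the thiocarbonyl carbon.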